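The source may report more compounds than this note shows. Statements on the series, on what has been measured and on what is new or still open speak of the compounds shown alone.

Working notes on the series. In a functional assay on M21 cells (Homo sapiens) for antiproliferative activity, read by sulforhodamine B assay, with a stated time of 48 h (on this read-out lower numbers stand for stronger inhibition and higher numbers for weaker inhibition), compound 1 `O=C1NCCN1c1ccc(S(=O)(=O)Nc2ccccc2)cc1` gives 200 nM and compound 2 `O=C1NCCN1c1ccc(S(=O)(=O)Nc2ccc(Br)cc2)cc1` gives 130 nM. For the measured compounds named here, these two values lie within the scatter of each other, so compound 2 is not separated from the only other measured compound. Next is compound 3 `CCCCCCOc1ccc(NS(=O)(=O)c2ccc(N3CCNC3=O)cc2)cc1`, with hexyloxy in place of bromo on an aromatic carbon. Going by the values given here, one measured step bears on this carbon, a 1.5-fold lower number from compound 1 to compound 2 (0.19 log units; within the scatter), and it is small. Among the compounds with values here, it covers only hydrogen and bromo, and no measured compound carries a chain at this place, so the data give only weak guidance on size or direction. In this assay, a modest move to a higher number is tentatively expected, a 2.3-fold higher number from compound 2 to compound 3 (0.36 log units; beyond the scatter). For compound 3 the estimated value is 300 nM, with an expected range of 80 nM to 1500 nM.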

Compound 3, half-maximal inhibitory concentration: > 1000 nM
Compound 3 ended at the assay's limit; the forecaster's own chance of this, stated with the estimate: 5%; middle value at least 3.3-fold (0.52 log units) from the limit.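

In this assay compound 3 reads > 1000 nM, which is a limit of the assay and not a number: the limit of > 1000 nM in this assay, at which 1 of the 3 values shown sits. Hydrogen and bromo on this aromatic carbon were not separated, but hexyloxy is separated from both, with an at least 7.6-fold higher number from compound 2 to compound 3 (0.88 log units; beyond the scatter) and an at least 5.0-fold higher number from compound 1 to compound 3 (0.69 log units; beyond the scatter). The position is therefore not indifferent to what it carries, and a hexyloxy chain here goes with weaker inhibition, by an amount that the limit leaves without an upper bound.

The compounds shown do not tell whether this shift goes with the length of the chain or with its oxygen, a question that methoxy and plain hexyl at this carbon would bear on. They also leave open how an amine or a carboxylic acid would read at this place.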